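The source may report more compounds than this note shows. Statements on the series, on what has been measured and on what is new or still open speak of the compounds shown alone.

Measured in a functional assay on HT-29 cells (Homo sapiens) for antiproliferative activity, read by sulforhodamine B assay, with a stated time of 48 h; on this read-out lower numbers stand for stronger inhibition and higher numbers for weaker inhibition:
Compound 1 `O=C1NCCN1c1ccc(S(=O)(=O)Nc2ccc(F)cc2)cc1`: 370 nM
Compound 2 `O=C1NCCN1c1ccc(S(=O)(=O)Nc2ccc(F)c(F)c2)cc1`: 350 nM

Within the data shown here, compound 2 stands level with the only other number available, and a 1.1-fold lower number from compound 1 to compound 2 (0.02 log units; within the scatter) is the single measured step, fluoro in place of hydrogen on an aromatic carbon. Compound 3 `Cc1ccc(C)c(NS(=O)(=O)c2ccc(N3CCNC3=O)cc2)c1` instead carries 2,5-dimethylphenyl in place of 3,4-difluorophenyl on a sulfonamide nitrogen. No methyl group has been measured here, so that one small step is weak guidance, and no change beyond the scatter is expected in this assay. The expected step is a 1.2-fold lower number from compound 2 to compound 3 (0.07 log units; within the scatter). For compound 3 the estimate is 300 nM, with an expected range of 80 nM to 1100 nM.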

Compound 3, half-maximal inhibitory concentration: 46 nM
The estimate for compound 3 lay 6.5-fold (0.81 log units) above the measured number, outside the stated range (below it).
By their numbers in this assay, from the lowest: compound 3; then compounds 2 and 1 (each within the scatter of the next).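

In this assay, the group on the sulfonamide nitrogen can move the number beyond the scatter: 2,5-dimethylphenyl gives a 7.6-fold lower number from compound 2 to compound 3 (0.88 log units; beyond the scatter) when it replaces 3,4-difluorophenyl and an 8.0-fold lower number from compound 1 to compound 3 (0.91 log units; beyond the scatter) when it replaces 4-fluorophenyl. The earlier fluoro change at this position stayed within the scatter. Nothing available here accounts for the gain.

The compounds shown do not separate the contributions of the two methyl groups. As far as these compounds go, it remains open how a single methyl, a methoxy group or an amine on this aromatic ring would read.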